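Capping the piperidine hydroxyl: a methyl step

The compounds below may be only part of what the source reports. "The series", "measured", "known", "first", "only" and "open" are said of these compounds alone.

Measured so far:
compound 1, `CCN(CC)S(=O)(=O)c1ccc(S(=O)(=O)N2CCC[C@@H](C(=O)N[C@H]3CC[C@H](OC)CC3)C2)cc1` — 2000 nM
compound 2, `CCN(CC)S(=O)(=O)c1ccc(S(=O)(=O)N2CCC[C@@H](C(=O)N3CCC(O)CC3)C2)cc1` — 4710 nM

Both compounds share one core and differ only in the group on the carbonyl carbon. Going by the values given here, in a functional assay on BXPC-3 cells (Homo sapiens) for inhibition, read by MTT assay, with a stated time of 7 days (a lower number here means a stronger inhibitor, a higher number a weaker inhibitor), compound 2 gives the higher of the two numbers; the only measured step, a 2.4-fold higher number from compound 1 to compound 2 (0.37 log units; beyond the scatter), is modest but beyond the scatter, so compound 2 is the weaker of the pair in this assay.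

Compound 3, `CCN(CC)S(=O)(=O)c1ccc(S(=O)(=O)N2CCC[C@@H](C(=O)N3CCC(OC)CC3)C2)cc1`, has not yet been measured. It differs from compound 2 by methyl in place of hydrogen on an oxygen on a saturated carbon, that is, hydroxy to methoxy on the 4-hydroxypiperidin-1-yl group.

Among the compounds with values here, no measured step isolates this change. The step from compound 1 to compound 2 swaps both the amine and the oxygen substituent at once, so it bears on compound 3 only loosely: compound 1, which carries a methoxy on its ring, gives the lower number, but its ring and amide are different. The expectation is therefore a step in this assay of about a 1.3-fold lower number from compound 2 to compound 3 (0.13 log units; within the scatter), that is, little or no change beyond the scatter, leaning slightly toward a lower number.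

For compound 3 the estimate in this assay is 3500 nM, with a range from 1500 nM to 8000 nM.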

Compound 3, half-maximal inhibitory concentration: 1420 nM
The estimate for compound 3 lay 2.5-fold (0.39 log units) above the measured number; the whole stated range lies above it.
By their numbers in this assay, from the lowest: compounds 3 and 1 (each within the scatter of the next); then compound 2.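

In this assay, the change from hydroxy to methoxy on the 4-hydroxypiperidin-1-yl group can now be read on its own: a 3.3-fold lower number from compound 2 to compound 3 (0.52 log units; beyond the scatter), which is beyond the scatter, so adding a methyl on this oxygen is enough to shift the number, whereas the earlier step changed the amine and the oxygen substituent together. The other new step, a 1.4-fold lower number from compound 1 to compound 3 (0.15 log units; within the scatter), lies within the scatter, so with a methoxy in place, 4-methoxypiperidin-1-yl and (4-methoxycyclohexyl)amino on the carbonyl carbon cannot be told apart in this assay, and among these three compounds only the hydroxy compound stands apart. No measurement at hand accounts for the size of the methyl step.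

The compounds shown leave open whether the gain depends on the methoxy itself or simply on the hydroxy being gone, a question that an ethoxy, a fluorine or a plain hydrogen at this place on the piperidine would address. They also leave open whether a hydroxy on the cyclohexyl ring of the amide would raise the number in the same way.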